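A few compounds are considered here, and "the series" means these few. Any claim that something is new, unique, unknown or untested is made for them only; others in the source may bear on it.

In a functional assay on HL-60 cells (Homo sapiens) for antiproliferative activity, with a stated time of 72 h (a higher number here means a weaker inhibitor, a lower number a stronger inhibitor), compound 1 `OC[C@H]1O[C@@H](n2cnc3c(NCc4ccc(F)cc4)ncnc32)[C@H](O)[C@@H]1O` gives 1200 nM. Compound 2 `Cc1ccc(CNc2ncnc3c2ncn3[C@@H]2O[C@H](CO)[C@@H](O)[C@H]2O)cc1` gives > 166000 nM, which is a limit and not a number. Compound 2 stands at the limit of > 166000 nM in this assay, at which 1 of the 2 values shown sits. Going by the values given here, the only measured step, an at least 130-fold higher number from compound 1 to compound 2 (2.14 log units; beyond the scatter), puts methyl in place of fluoro on an aromatic carbon and is large, beyond the scatter.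

Compound 3 `OC[C@H]1O[C@@H](n2cnc3c(NCc4ccc(Cl)cc4Cl)ncnc32)[C@H](O)[C@@H]1O` differs from compound 2 on a saturated chain carbon bound to a nitrogen on an aromatic ring: 2,4-dichlorophenyl in place of 4-methylphenyl on a saturated chain carbon bound to a nitrogen on an aromatic ring. Here 2,4-dichlorophenyl takes the place of 4-methylphenyl, so the methyl of that step is gone, although no measured step covers chlorine. A large step toward lower numbers is therefore expected in this assay, on the strength of an at least 130-fold higher number from compound 1 to compound 2 (2.14 log units; beyond the scatter) read in reverse. The expected step is an at least 27-fold lower number from compound 2 to compound 3 (1.44 log units; beyond the scatter). For compound 3 the estimated value is 6000 nM, with an expected range of 800 nM to 60000 nM.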

Compound 3, half-maximal inhibitory concentration: 96300 nM
The estimate for compound 3 lay 16-fold (1.21 log units) below the measured number; measured number outside the range, above it.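

In this assay, compound 3 shows that the loss at this saturated chain carbon bound to a nitrogen on an aromatic ring is not confined to 4-methylphenyl, as 2,4-dichlorophenyl in place of 4-fluorophenyl also brings a large change (an 80-fold higher number from compound 1 to compound 3 (1.90 log units; beyond the scatter)). Compound 1 is thus the strongest of the three, with both replacements of its 4-fluorophenyl giving much higher numbers. The step between the other two (an at least 1.7-fold lower number from compound 2 to compound 3 (0.23 log units; that floor lies within the scatter)) has a floor within the scatter and sets no order between 4-methylphenyl and 2,4-dichlorophenyl, and compound 2 is held only at a limit: (the limit of > 166000 nM in this assay, at which 1 of the 3 values shown sits).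

The compounds shown leave open how 4-chlorophenyl or unsubstituted phenyl would read at this place. They also leave open whether a single chlorine would stay closer to compound 1 than the two chlorines of compound 3 do.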